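Amino in Place of Methoxy, Tested on Two Cores

The compounds below may be only part of what the source reports. "The series", "measured", "known", "first", "only" and "open" are said of these compounds alone.

Compound 1 `Nc1ncnc2c1ncn2C[C@@H]1C[C@H](O)c2ccccc21` gives in an ADME assay on L1210/0 cells (Mus musculus) for cytotoxicity, with a stated time of 48 h; on this read-out lower numbers stand for stronger inhibition and higher numbers for weaker inhibition > 200000 nM, which is a limit of the assay and not a number.
Compound 2 `COc1ncnc2c1ncn2C[C@@H]1C[C@H](O)c2ccccc21` gives in this assay > 200000 nM, again a limit rather than a number.
Compound 3 `COc1nc(I)nc2c1ncn2COCCO` gives in this assay > 200000 nM, also only a limit.

From compound 2 to compound 1 the change is amino in place of methoxy on an aromatic carbon and the step is a step that the two limits leave unreadable from compound 2 to compound 1. All that is known of it rests on (the limit of > 200000 nM in this assay, at which 3 of the 3 values shown sit).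

Compound 4 `Nc1nc(I)nc2c1ncn2COCCO` is still to be measured. It differs from compound 3 by amino in place of methoxy on an aromatic carbon. The surroundings of the place are not identical: on the core of compound 3 the carbon is also meta to an iodo group (1 heavy atom), so this is the same kind of change, not the same one. How the core of compound 3 differs from that of compound 2 is not broken down here.

The step from compound 3 to compound 4 is expected to be a number no higher from compound 3 to compound 4 (the limit leaves the size open), because both ends of the earlier step sit at the limit of > 200000 nM in this assay, at which 3 of the 3 values shown sit. Compound 4 is therefore expected to give about 200000 nM, most likely again reported only as a limit.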

Compound 4, half-maximal inhibitory concentration: > 200000 nM
Compound 4: no number, only a limit; the forecaster's own chance of this, stated with the estimate: 80%; the middle value sits exactly at the limit.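

Compound 3 and compound 4 each give only a limit of the assay and not a number, so no step can be read between them: the limit of > 200000 nM in this assay, at which 4 of the 4 values shown sit.

The compounds shown leave open whether amino in place of methoxy changes the result in this assay on either core, and what structure would give a measurable number there.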